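The source may report more compounds than this note shows. Statements on the series, on what has been measured and on what is new or still open speak of the compounds shown alone.

Compound 1 `Cc1ccoc1C(=O)N1CCC(NC(=O)Nc2ccc(C(F)(F)F)cc2)CC1` and compound 2 `Cc1ccoc1C(=O)N1CCC(NC(=O)Nc2ccc(OC(F)(F)F)cc2)CC1` share one core and differ in a single group on the aromatic ring. In a physicochemical assay for lipophilicity, read by HPLC, with a stated time of 90 min, tested at 100 uM (a lower number here means a more polar compound, a higher number a more lipophilic compound), compound 1 gives 4.29, and compound 2 gives 4.48. The change between them is trifluoromethoxy in place of trifluoromethyl on an aromatic carbon, and it made a step of a number 0.19 log units higher from compound 1 to compound 2 (within the scatter).

Compound 3 `O=C(Nc1ccc(C(F)(F)F)c(F)c1)NC1CCN(C(=O)[C@@H]2CCOC2)CC1` rests on a different core, and the difference between the two cores is not broken down here. In this assay, for the measured compounds named here, compound 3 gives 3.41, the lowest of the three numbers measured so far, beyond the scatter from both compound 1 and compound 2.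

Compound 4 `O=C(Nc1ccc(OC(F)(F)F)c(F)c1)NC1CCN(C(=O)[C@@H]2CCOC2)CC1` has not yet been measured. It stands to compound 3 as compound 2 stands to compound 1: the change is trifluoromethoxy in place of trifluoromethyl on an aromatic carbon. Going by the values given here, this is the same kind of change as the one from compound 1 to compound 2, though not the same in every respect, since in compound 4 the new group sits ortho to a fluoro group, which the place in compound 2 does not have. The change occurs twice among the compounds shown, once measured and once not.

Among the compounds with values here, for compound 4 in this assay a step of about a number 0.19 log units higher from compound 3 to compound 4 (within the scatter) is expected, on the strength of the step from compound 1 to compound 2, which is the only measured example of this change. On that basis compound 4 is expected to give about 3.6, most likely between 3.35 and 3.85.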

Compound 4, partition coefficient: 3.59
Estimate against measurement, compound 4: 0.01 log units above; the range from low to high includes it.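

In this assay the change to trifluoromethoxy in place of trifluoromethyl gives a number 0.18 log units higher from compound 3 to compound 4 (within the scatter) and, on the other core, gave a number 0.19 log units higher from compound 1 to compound 2 (within the scatter) in the earlier pair, so the two printed steps look alike on both cores, even though in compound 4 the new group sits ortho to a fluoro group. Each step lies within the usual scatter of repeated measurements, so neither pair alone shows that this change truly moves the number, and two pairs on two cores are too few to make a rule for the whole series. Nothing measured here explains why the two steps look alike.

The compounds shown leave open whether the same small step would appear with another group in that place on the aromatic ring, such as a nitrile or a methoxy group, or on a core that carries an amine or a carboxylic acid. They also leave open what the fluoro group contributes, since no pair shown makes this change on one core both with and without that fluoro group.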